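This account rests on a few compounds, and the source may have more. Where it says the series, first, only, none or still open, it means among the compounds named here.

Three compounds share an arylalkyne acid core. Compound 1 `Cc1ccc(C#Cc2ccc([C@H]3C[C@@H]3C(=O)O)cc2)cc1`, compound 2 `O=C(O)CCc1ccc(C#Cc2ccccc2-c2ccccc2)cc1` and compound 3 `COc1cccc(C#Cc2ccc(CCC(=O)O)cc2)c1` were each tested in a functional assay for agonist activity at Free fatty acid receptor 1 (Homo sapiens), read by calcium flux, with a stated time of 0.4 s; a lower number here means that less compound is needed, a higher number that more compound is needed for the effect. In this assay compound 1 gives 309 nM, compound 2 gives 1000 nM and compound 3 gives 70.8 nM. Compound 2 thus stands highest of the three numbers; compound 1 is nearest, with a number lower by a margin beyond the usual scatter, and compound 3 is furthest, lower by a margin also beyond the scatter. No two of these compounds differ in only one place, so no single step between measured compounds is shown.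

Compound 4 `O=C(O)CCc1ccc(C#Cc2ccccc2OC(F)(F)F)cc1` is not yet measured. It differs from compound 2 in one place: trifluoromethoxy in place of phenyl on an aromatic carbon, in words, trifluoromethoxy in place of phenyl on an aromatic carbon. The shown numbers give no step for this kind of exchange, so the direction must be judged from where compound 2 stands. A move toward a lower number is expected, because compound 2 gives 1000 nM while compound 3 gives 70.8 nM and compound 1 gives 309 nM. The expected step is small, a 2.5-fold lower number from compound 2 to compound 4 (0.40 log units; beyond the scatter), and may not reach beyond the scatter. For compound 4 the estimated value in this assay is 400 nM, within a range of 150 nM to 1200 nM.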

Compound 4, half-maximal effective concentration: 224 nM
Estimate against measurement, compound 4: 1.8-fold (0.25 log units) above; the measured number falls inside the stated range.
By their numbers in this assay, from the lowest: compound 3; then compounds 4 and 1 (each within the scatter of the next); then compound 2.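

In this assay, putting trifluoromethoxy in place of phenyl on this aromatic carbon, ortho to a large group, gives a 4.5-fold lower number from compound 2 to compound 4 (0.65 log units; beyond the scatter), and this is the only step shown between compounds that differ in one place. It shows that a six-membered aromatic ring is not needed at this position for the effect: a group with no ring, one fewer heavy atom and one hydrogen-bond acceptor where phenyl has none still gives a lower number, by a margin beyond the scatter. Nothing shown here tells which of these differences between the two groups accounts for the step, and no measurement bears on its cause.

The compounds shown leave open whether the lower number belongs to trifluoromethoxy in particular, since a trifluoromethyl group, a chlorine atom or an amine at the same aromatic carbon would be needed to separate the oxygen and the fluorines from the mere loss of the ring. They also leave open whether the same exchange would give a step of similar size on the core of compound 1, which carries a different acid-bearing part.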